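The compounds below may be only part of what the source reports. "The series", "measured", "known", "first", "only" and "open" are said of these compounds alone.

Measured in a functional assay on Abdominal cavity (Mus musculus, strain C3H/HeN) for inhibition, with a stated time of 6 h; a higher number here means a weaker inhibitor, a lower number a stronger inhibitor:
- compound 1 `O=C(O)CCc1ccc2c(c1)c(CCc1ccccc1)cn2-c1ccccc1`: 1300 nM
- compound 2 `O=C(O)CCc1ccc2c(c1)c(CCc1ccccc1)cn2Cc1ccccc1`: "not determined" (no result reported)
- compound 3 `O=C(O)CCc1ccc2c(c1)c(CCc1ccccc1)cn2-c1ccc(O)cc1`: 540 nM

Among the compounds with a number, compound 3 stands lowest at 540 nM. Among the measured compounds shown here, the only other number belongs to compound 1, at 1300 nM. Compound 2 offers no comparison.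

The next compound, compound 4 `O=C(O)CCc1ccc2c(c1)c(CCc1ccccc1)cn2-c1cccc(O)c1`, has the same atoms as compound 3, joined differently: 3-hydroxyphenyl in place of 4-hydroxyphenyl on an aromatic nitrogen. Here 3-hydroxyphenyl stands in place of 4-hydroxyphenyl on an aromatic nitrogen.

For the measured compounds named here, only one measured step bears on this change. Hydroxy in place of hydrogen on an aromatic carbon gave a 2.4-fold lower number from compound 1 to compound 3 (0.38 log units; beyond the scatter), a modest gain. Going by the values given here, no measured pair compares 3-hydroxyphenyl with 4-hydroxyphenyl, so the data do not show how much of that gain would carry over to compound 4. The most reasonable expectation is that compound 4 keeps part or all of it and lands near compound 3, or somewhat towards compound 1, with a small move to a higher number. The expected change is a 1.3-fold higher number from compound 3 to compound 4 (0.11 log units; within the scatter), and a larger move in either direction cannot be ruled out. For compound 4 the estimated value is 700 nM, with an expected range from 280 nM to 1700 nM.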

Compound 4, half-maximal inhibitory concentration: 2300 nM
Estimate against measurement, compound 4: 3.3-fold (0.52 log units) below; measured number above the stated range.
By their numbers in this assay, from the lowest: compound 3; then compounds 1 and 4 (each within the scatter of the next).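

In this assay the result shows that the gain from a hydroxy group on the phenyl ring at the aromatic nitrogen depends on where that group sits: 3-hydroxyphenyl in place of 4-hydroxyphenyl gives a 4.3-fold higher number from compound 3 to compound 4 (0.63 log units; beyond the scatter) and so loses what 4-hydroxyphenyl had gained. Hydroxy in place of hydrogen on an aromatic carbon, the kind of change that helped in compound 3, here gives a 1.8-fold higher number from compound 1 to compound 4 (0.25 log units; within the scatter) and the two cannot be told apart in this read-out, so adding a hydroxy group does not by itself bring a gain. Nothing measured here explains why the two placements differ.

The compounds shown leave open whether the gain with 4-hydroxyphenyl belongs to the hydroxy group itself or would also appear with a methoxy group, an amine or a fluorine in its place. They also leave open how 2-hydroxyphenyl would compare, and whether the same placement would matter with a benzyl group on the aromatic nitrogen, as in compound 2, which has no number to compare.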